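A few compounds are considered here, and "the series" means these few. Any claim that something is new, unique, unknown or untested is made for them only; others in the source may bear on it.

Compound 1 `O=S(=O)(NC1=NCCN1C(=S)SN1CCn2c1nsc2=S)c1ccccc1`: in a functional assay on KYSE-510 cells (Homo sapiens) for antiproliferative activity, read by crystal violet staining, with a stated time of 96 h (on this read-out lower numbers stand for stronger inhibition of growth and higher numbers for weaker inhibition of growth), compound 1 gives only the limit >= 20000 nM.
Compound 2 `Cc1ccc(S(=O)(=O)NC2=NCCN2C(=S)SN2CCn3c2nsc3=S)cc1`: in this assay compound 2 gives only the limit >= 20000 nM.

Both measured values are limits of this assay rather than numbers. The step that the two limits leave unreadable from compound 1 to compound 2 is therefore unreadable, as the limit of >= 20000 nM in this assay, at which 2 of the 2 values shown sit, shows both ends resting at the same limit. Compound 2 thus stands at the limit of this assay, with no number of its own, and no order between compound 2 and compound 1 can be drawn.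

Compound 3 `Cc1cc(C)c(S(=O)(=O)NC2=NCCN2C(=S)SN2CCn3c2nsc3=S)c(C)c1` has not yet been measured in this assay. It differs from compound 2 by 2,4,6-trimethylphenyl in place of 4-methylphenyl on a sulfonyl sulfur. Among the measured compounds shown here, the only measured step that touches the same part of the molecule is a step that the two limits leave unreadable from compound 1 to compound 2, which gives no readable size, so the data offer no measured basis for a direction. Since the limit of >= 20000 nM in this assay, at which 2 of the 2 values shown sit, places every measured value at the limit, compound 3 is expected to remain there as well: the estimate for compound 3 is 20000 nM, with a range from 6000 nM to 60000 nM. The expected step is a number no higher from compound 2 to compound 3 (the limit leaves the size open), that is, none beyond the scatter.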

Compound 3, concentration for 50% growth inhibition: >= 20000 nM
Compound 3: a limit, no number; the forecaster's own chance of this, stated with the estimate: 70%; the middle value lies on the limit itself.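

In this assay no step can be read among compound 1, compound 2 and compound 3, because all three rest at the same limit: the limit of >= 20000 nM in this assay, at which 3 of the 3 values shown sit.
The compounds shown leave open how strongly any of them inhibits growth, and whether phenyl, 4-methylphenyl or 2,4,6-trimethylphenyl on a sulfonyl sulfur makes any difference.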